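A few compounds are considered here, and "the series" means these few. Any claim that something is new, unique, unknown or untested is made for them only; others in the source may bear on it.

Measured compounds:
compound 1 `C#CCOc1ccc(-c2cc(-c3ccccc3OCC#C)nc(N)n2)cc1`: 22100 nM
compound 2 `C#CCOc1ccc(-c2cc(-c3ccc(OCC#C)cc3)nc(-c3ccccc3)n2)cc1`: 12300 nM
compound 3 `C#CCOc1ccc(-c2cc(-c3ccc(OCC#C)cc3)nc(N)n2)cc1`: 3300 nM

In an assay on BTI-TN-5B1-4 cells for inhibition of Amine oxidase [flavin-containing] B (Homo sapiens), read by fluorescence and Amplex Red, using microsomes, with a stated time of 30 min (on this read-out lower numbers stand for stronger inhibition and higher numbers for weaker inhibition), compound 2 gives 12300 nM, the second highest of the three numbers; compound 1 is within the scatter of it, and compound 3 lies beyond the scatter on the lower side. For the measured compounds named here, the only step between compounds differing in one place is a 3.7-fold lower number from compound 2 to compound 3 (0.57 log units; beyond the scatter), which does not touch the change considered here. Compound 4 `C#CCOc1ccc(-c2cc(-c3ccccc3OCC#C)nc(-c3ccccc3)n2)cc1` differs from compound 2 by a group of 10 heavy atoms (9 carbon, 1 oxygen; one six-membered aromatic ring of carbon only) in place of a group of 10 heavy atoms (9 carbon, 1 oxygen; one six-membered aromatic ring of carbon only), on an aromatic carbon. Going by the values given here, no step covers this rearrangement directly; what can be drawn on is the pair of compound 1 and compound 3, which show the same rearrangement on the amino-bearing core: compound 1 gives 22100 nM, compound 3 gives 3300 nM, the former the higher number. On that basis a higher number in this assay is expected for compound 4, with a step of roughly a 4.1-fold higher number from compound 2 to compound 4 (0.61 log units; beyond the scatter) from compound 2. Among the compounds with values here, compound 4 is estimated at 50000 nM, with a range of 15000 nM to 160000 nM, the spread being wide since only one comparable pair exists.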

Compound 4, half-maximal inhibitory concentration: 14400 nM
Beside the measured number, compound 4's estimate is 3.5-fold (0.54 log units) above it; the measured number lies below the stated range.
By their numbers in this assay, from the lowest: compound 3; then compounds 2, 4 and 1 (each within the scatter of the next).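

In this assay, exchanging the 4-(propargyloxy)phenyl group for the rearranged group of compound 4 gives a 1.2-fold higher number from compound 2 to compound 4 (0.07 log units; within the scatter), so on the core of compound 2 this position shows no effect of the rearrangement that can be told from the scatter. Phenyl in place of amino, with the rearranged group present, gives a 1.5-fold lower number from compound 1 to compound 4 (0.19 log units; within the scatter), so this exchange also shows no effect that can be told from the scatter, unlike the same exchange with the 4-(propargyloxy)phenyl group in place. The two changes therefore do not add independently, and the effect of amino against phenyl depends on the group at this position: the same change on two cores in this assay, a 3.7-fold lower number (0.57 log units; beyond the scatter) from compound 2 to compound 3 and a 1.5-fold higher number (0.19 log units; within the scatter) from compound 4 to compound 1, 5.7-fold (0.76 log units) apart, beyond the scatter of two such steps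

As far as these compounds go, whether this dependence holds with a methylamino or methoxy group in place of amino or phenyl remains open. The compounds shown also leave open how a longer chain than propargyl on the oxygen would behave at this position.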